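Working notes: from compound 3 to compound 4

A few compounds are considered here, and "the series" means these few. Any claim that something is new, unique, unknown or untested is made for them only; others in the source may bear on it.

Measured in an ADME assay on L6 cells (Rattus norvegicus) for cytotoxicity, read by resazurin assay, with a stated time of 72 h; a lower number here means a stronger inhibitor, a higher number a weaker inhibitor:
- compound 1 `OC(c1ccc(Cl)cc1)(c1cncnc1)c1ccccc1F`: > 100000 nM (a limit)
- compound 2 `OC(c1ccc(Cl)cc1)(c1cccnc1)c1ccccc1Br`: 55200 nM
- compound 3 `OC(c1ccc(Cl)cc1)(c1cccnc1)c1cccc(Br)c1`: 54100 nM

Compound 3 sits within the scatter of compound 2, as a 1.0-fold lower number from compound 2 to compound 3 (0.01 log units; within the scatter) shows. That step only swaps 2-bromophenyl for 3-bromophenyl, so it gives no size for the next change. Compound 4 `OC(c1ccc(Cl)cc1)(c1cccnc1)c1cncnc1` carries pyrimidin-5-yl in place of 3-bromophenyl on a saturated chain carbon bound to two aromatic carbons and an oxygen on a saturated carbon. The closest guide is compound 1, which also carries pyrimidin-5-yl and reads > 100000 nM, a limit. A modest move to a higher number in this assay is therefore expected, an estimated 1.6-fold higher number from compound 3 to compound 4 (0.20 log units; within the scatter). For compound 4 the estimate is 85000 nM, with an expected range of 45000 nM to 160000 nM.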

Compound 4, half-maximal inhibitory concentration: > 100000 nM
Compound 4: no number, only a limit (the forecaster's own chance of this, stated with the estimate: 40%); at least 1.1-fold (0.07 log units) between middle value and limit.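

In this assay, pyrimidin-5-yl in place of 3-bromophenyl on this saturated chain carbon gives an at least 1.8-fold higher number from compound 3 to compound 4 (0.26 log units; that floor lies within the scatter), and in place of 2-bromophenyl it gives an at least 1.8-fold higher number from compound 2 to compound 4 (0.25 log units; that floor lies within the scatter). Compound 4 reads only as a limit, so these steps give floors and not sizes, and the step from compound 1 to compound 4 cannot be read. Both compounds carrying pyrimidin-5-yl stand at that limit: the limit of > 100000 nM in this assay, at which 2 of the 4 values shown sit.

As far as these compounds go, how far compound 4 lies past its limit stays open. So does the reading of an aminophenyl or a carboxyphenyl group at this place.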